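Benzyl Amine Variation on a Bis(trifluoromethyl) Sulfonamide Series

A few compounds are considered here, and "the series" means these few. Any claim that something is new, unique, unknown or untested is made for them only; others in the source may bear on it.

Compound 1, `O=S(=O)(NCCCCNCc1ccc(Br)cc1)c1cc(C(F)(F)F)cc(C(F)(F)F)c1`: 2900 nM in a functional assay on ASPC1 cells (Homo sapiens) for inhibition, read by MTT assay, with a stated time of 72 h; on this read-out higher numbers stand for weaker inhibition of growth and lower numbers for stronger inhibition of growth
Compound 2, `O=S(=O)(NCCCNCc1ccc(Cl)cc1)c1cc(C(F)(F)F)cc(C(F)(F)F)c1`: 3000 nM
Compound 3, `CC(C)(C)c1ccc(CNCCCNS(=O)(=O)c2cc(C(F)(F)F)cc(C(F)(F)F)c2)cc1`: 2700 nM

The three measured compounds share one core and differ only in the benzyl amine end. Among the compounds with values here, compound 3 stands among them with a value that cannot be told apart from the other two: the step of a 1.0-fold higher number from compound 1 to compound 2 (0.01 log units; within the scatter) and the step of a 1.1-fold lower number from compound 2 to compound 3 (0.05 log units; within the scatter) both sit inside the scatter, so no compound can be called more or less potent than another.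

Compound 4, `COc1cccc(CNCCCNS(=O)(=O)c2cc(C(F)(F)F)cc(C(F)(F)F)c2)c1`, is not yet measured. It differs from compound 3 in one place, (3-methoxyphenyl in place of 4-(tert-butyl)phenyl on a saturated chain carbon bound to an amine nitrogen). The step that bears most directly on this change is a 1.1-fold lower number from compound 2 to compound 3 (0.05 log units; within the scatter), where exchanging a tert-butyl for a chloro on an aromatic carbon moved nothing beyond the scatter; the step of a 1.0-fold higher number from compound 1 to compound 2 (0.01 log units; within the scatter), a change of halogen and chain length, likewise left the number unchanged. Within the data shown here, no measured compound carries a 3-methoxyphenyl, so the expectation rests on these two flat steps.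

On that basis compound 4 is expected to show a 1.0-fold higher number from compound 3 to compound 4 (0.02 log units; within the scatter), a step of no real size. The estimate for compound 4 in this assay is 2800 nM, within the range 1300 nM to 6000 nM.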

Compound 4, concentration for 50% growth inhibition: 3800 nM
Compound 4: the middle estimate sits 1.4-fold (0.13 log units) below what was measured, within the range that was stated.
By their numbers in this assay, from the lowest: compounds 3, 1, 2 and 4 (each within the scatter of the next).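

Within the data shown here, replacing 4-(tert-butyl)phenyl with 3-methoxyphenyl on a saturated chain carbon bound to an amine nitrogen gives a 1.4-fold higher number from compound 3 to compound 4 (0.15 log units; within the scatter) in this assay, so a group with a methoxy oxygen and one hydrogen-bond acceptor, where the group it replaces has none, does not separate from the earlier compounds. The comparisons with the halogen-bearing compounds read the same way: 3-methoxyphenyl in place of 4-chlorophenyl gives a 1.3-fold higher number from compound 2 to compound 4 (0.10 log units; within the scatter), and (3-methoxybenzyl)amino in place of ((4-bromobenzyl)amino)methyl gives a 1.3-fold higher number from compound 1 to compound 4 (0.12 log units; within the scatter). Among these compounds, the flat picture, earlier seen only with 4-bromobenzyl, 4-chlorobenzyl and 4-(tert-butyl)benzyl ends, therefore now also covers 3-methoxybenzyl, though no measurement at hand explains that flatness.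

Going by these compounds, whether it would survive a benzyl end carrying a carboxylic acid, a hydroxyl or a nitrile, or a plain unsubstituted benzyl, remains open. Also open, on these data alone, is what an amide in place of the amine, or another group in place of the two trifluoromethyl groups on the shared core, would do, as all four compounds keep both features unchanged.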